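A few compounds are considered here, and "the series" means these few. Any claim that something is new, unique, unknown or untested is made for them only; others in the source may bear on it.

Compound 1 `COc1ccccc1-c1cnc(C(=O)CCCCCCc2ccccc2)o1`: 400 nM
Compound 2 `O=C(O)c1ccc(-c2cnc(C(=O)CCCCCCc3ccccc3)o2)cc1`: 60 nM
Compound 3 `N#Cc1ccc(-c2cnc(C(=O)CCCCCCc3ccccc3)o2)cc1`: 40 nM

In an assay (Rattus norvegicus) for inhibition of Fatty-acid amide hydrolase 1 (Homo sapiens) (a lower number here means a stronger inhibitor, a higher number a weaker inhibitor), compound 1 gives the highest of these three numbers. Compound 4 `Cc1ccc(-c2cnc(C(=O)CCCCCCc3ccccc3)o2)nc1` differs from compound 1 in one place: 5-methylpyridin-2-yl in place of 2-methoxyphenyl on an aromatic carbon. Within the data shown here, two measured steps bear on this, since each also removes 2-methoxyphenyl from that aromatic carbon and each lowered the number beyond the scatter: a 6.7-fold lower number from compound 1 to compound 2 (0.82 log units; beyond the scatter) and a 10-fold lower number from compound 1 to compound 3 (1.00 log units; beyond the scatter). The group entering in compound 4 is not the same kind as in compound 2 or compound 3, so a smaller lowering seems more likely than a matching one, though the direction is expected to be the same. Compound 4 is therefore expected to give about 150 nM, between 50 nM and 500 nM. The expected step is a 2.7-fold lower number from compound 1 to compound 4 (0.43 log units; beyond the scatter).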

Compound 4, inhibition constant: 2.8 nM
The estimate for compound 4 lay 54-fold (1.73 log units) above the measured number, outside the stated range (below it).
By their numbers in this assay, from the lowest: compound 4; then compounds 3 and 2 (each within the scatter of the next); then compound 1.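

At this aromatic carbon next to the ring oxygen, the choice of group matters more than compounds 1, 2 and 3 showed: 5-methylpyridin-2-yl gives a 140-fold lower number from compound 1 to compound 4 (2.15 log units; beyond the scatter) in this assay. It also goes clearly past both substituted phenyl groups, with a 14-fold lower number from compound 3 to compound 4 (1.15 log units; beyond the scatter) and a 21-fold lower number from compound 2 to compound 4 (1.33 log units; beyond the scatter). Nothing available here explains this gain.

As far as these compounds go, the change swaps a carbon-only ring for one with a ring nitrogen and also brings in a methyl, so the share of each remains open. Also open, from the compounds shown here alone, is how a pyridine ring without the methyl, or with an amine or a carboxylic acid in its place, would compare.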